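Bromophenyl for Chlorophenyl: An Expected Value for Compound 4

This account rests on a few compounds, and the source may have more. Where it says the series, first, only, none or still open, it means among the compounds named here.

Compound 1 `N#CC1=C(N)Oc2c(c3nc4ccccc4nc3c3ccccc23)C12C(=O)N(Cc1cnnn1-c1ccccc1Cl)c1ccccc12` gives, in a functional assay on HepG2 cells (Homo sapiens) for antiproliferative activity, read by MTT assay, with a stated time of 48 h (on this read-out lower numbers stand for stronger inhibition and higher numbers for weaker inhibition), a value that is a limit of the assay, > 50000 nM.
Compound 2 `N#CC1=C(N)Oc2c(c3nc4ccccc4nc3c3ccccc23)C12C(=O)N(Cc1cnnn1-c1cccc(Br)c1)c1ccccc12` gives in this assay a value that is also a limit, > 50000 nM.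
Compound 3 `N#CC1=C(N)Oc2c(N)cc3nc4ccccc4nc3c2C12C(=O)N(Cc1cnnn1-c1ccccc1Cl)c1ccccc12` gives in this assay 33500 nM.

Compound 1 and compound 2 share one core and differ by 3-bromophenyl in place of 2-chlorophenyl on an aromatic nitrogen. Both values sit at the limit, so a step that the two limits leave unreadable from compound 1 to compound 2; this rests on (the limit of > 50000 nM in this assay, at which 2 of the 3 values shown sit). Compound 3 carries a second core, and the difference between the two cores is not broken down here.

Compound 4 `N#CC1=C(N)Oc2c(N)cc3nc4ccccc4nc3c2C12C(=O)N(Cc1cnnn1-c1cccc(Br)c1)c1ccccc12` has not yet been measured. It stands to compound 3 as compound 2 stands to compound 1: the change is 3-bromophenyl in place of 2-chlorophenyl on an aromatic nitrogen, the same change made on the other core. Since the step on the first core cannot be read, the author expects compound 4 to remain near compound 3, with an estimated step of a 1.2-fold higher number from compound 3 to compound 4 (0.08 log units; within the scatter). The estimate for compound 4 in this assay is 40000 nM, expected to fall between 15000 nM and 100000 nM.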

Compound 4, half-maximal inhibitory concentration: > 50000 nM
Compound 4: only a limit was reported; the forecaster's own chance of this, stated with the estimate: 45%; at least 1.2-fold (0.09 log units) between middle value and limit.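

In this assay, moving to the core of compound 3, 3-bromophenyl in place of 2-chlorophenyl on an aromatic nitrogen gives an at least 1.4-fold higher number from compound 3 to compound 4 (0.17 log units; that floor lies within the scatter), a floor that does not by itself establish a real difference between the pair. Going by these compounds, the value of compound 4, > 50000 nM, is a limit of the assay and not a number, so the true size of the step remains unknown. The steps that end at limits on the other core cannot be read, so the data do not show whether this change behaves alike on the two cores: the limit of > 50000 nM in this assay, at which 3 of the 4 values shown sit.

The compounds shown carry only 2-chlorophenyl and 3-bromophenyl at this place, so the effect of the halogen cannot be told apart from that of its position on the phenyl ring. On these data alone, it also remains open whether a phenyl carrying an amine or a carboxylic acid there would give a readable value on either core.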